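A few compounds are considered here, and "the series" means these few. Any claim that something is new, unique, unknown or untested is made for them only; others in the source may bear on it.

Of the compounds shown here, three have so far been tested in an ADME assay on Vero cells (Chlorocebus sabaeus) for cytotoxicity, read by MTT assay, with a stated time of 72 h (on this read-out higher numbers stand for weaker inhibition and lower numbers for stronger inhibition), and all three share a methoxy-bearing core. Compound 1, `COc1ccc2c(N/N=C/c3ccc4ccccc4c3)ccnc2c1`, carries a naphthalene on its hydrazone arm, and in this assay compound 1 gives 0.454 ug/mL. Compound 2, `COc1ccc2nccc(N/N=C/C3CCCCC3)c2c1`, carries a saturated cyclohexyl ring instead, and in this assay compound 2 gives 5.03 ug/mL. Compound 3, `COc1cccc2c(N/N=C/c3ccc4ccccc4n3)ccnc12`, carries a quinoline on the arm, and in this assay compound 3 gives 1.68 ug/mL. On these three numbers compound 3 stands second highest: it lies between compound 1, whose number is lower by a gap beyond the usual scatter, and compound 2, whose number is higher by a gap also beyond the usual scatter.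

Compound 4, `COc1cccc2c(N/N=C/c3ccc4ccccc4n3)cc(C)nc12`, keeps everything of compound 3 and differs in one place only: methyl in place of hydrogen on an aromatic carbon. Among the compounds with values here, no pair among the measured compounds differs by a change of this kind, so nothing in the data sets the size of such a step. A single added methyl is a small change, and the expectation is a step from compound 3 to compound 4 of a 1.0-fold higher number from compound 3 to compound 4 (0.01 log units; within the scatter), in either direction, probably not beyond the usual scatter. Compound 4 is therefore estimated at 1.7 ug/mL, with a plausible range from 0.6 ug/mL to 4.5 ug/mL.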

Compound 4, half-maximal inhibitory concentration: 3.11 ug/mL
The estimate for compound 4 lay 1.8-fold (0.26 log units) below the measured number, and the stated range covers the measured number.
By their numbers in this assay, from the lowest: compound 1; then compounds 3, 4 and 2 (each within the scatter of the next, the first and the last beyond it).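

Within the data shown here, compound 3 and compound 4 form the first pair here that differs in one place only, so in this assay the size of this change can now be read directly: a 1.9-fold higher number from compound 3 to compound 4 (0.27 log units; within the scatter) for a methyl in place of hydrogen. This step stays within the scatter, so the two numbers cannot be told apart, and this aromatic carbon, next to the ring nitrogen, can carry a methyl without a clear shift on this read-out. No measurement shown here bears on the size of this step.

Going by these compounds, whether a bigger or different group on the same carbon, such as an ethyl chain, an amine or a carboxylic acid, would also leave the number unresolved from that of compound 3 remains open. Also open, on these data alone, is whether a methyl at this place would give a similar step in compounds with other arms, such as those of compound 1 and compound 2, since this single pair sets the size of the change for the quinoline-bearing arm alone.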